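Adding a methoxy group to the aryl ketone of compound 3

A few compounds are considered here, and "the series" means these few. Any claim that something is new, unique, unknown or untested is made for them only; others in the source may bear on it.

Of the compounds shown here, three have been tested so far in a functional assay on MCF7 cells (Homo sapiens) for antiproliferative activity, read by sulforhodamine B assay, with a stated time of 72 h, tested at 30 uM; a higher number here means a weaker effect of the compound at the concentration tested, a lower number a stronger effect. Compound 1 `COc1cccc(C(=O)/C=C/c2cc(Br)cc(OC)c2O)c1` gives 63.1% in this assay. Compound 2 `COC(=O)C1=C(N)Oc2c(OC)cc(Br)cc2C1CC(=O)c1cccc(OC)c1` gives 94.9%. Compound 3 `COc1cc(Br)cc2c1OC(N)=C(C#N)C2CC(=O)c1ccccc1` gives 36.7%, the lowest of the three numbers, which in this assay means the strongest effect; its nearest neighbour is compound 1, whose number lies higher by more than the scatter, and compound 2 lies further still.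

Compound 4 `COc1cccc(C(=O)CC2C(C#N)=C(N)Oc3c(OC)cc(Br)cc32)c1` has not yet been measured. It differs from compound 3 in one place: methoxy in place of hydrogen on an aromatic carbon. The group enters on an aromatic carbon of the six-membered aromatic ring of carbon only, meta to a large group, so that a phenyl becomes a 3-methoxyphenyl.

Going by the values given here, no measured pair shows this exact change, so the size of the step cannot be read off. The estimate for compound 4 in this assay is 45%, with a range from 25% to 70%. The expected step of a number 8.3 percentage points higher from compound 3 to compound 4 (within the scatter) is small, toward a slightly weaker effect, and may well lie within the scatter.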

Compound 4, a percentage reported as activity, at one concentration (the size of the read-out at that concentration, not a potency): 33.9%
The estimate for compound 4 lay 11.1 percentage points above the measured number, within the range that was stated.
By their numbers in this assay, from the lowest: compounds 4 and 3 (each within the scatter of the next); then compound 1; then compound 2.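

In this assay the step for methoxy in place of hydrogen on the aromatic carbon is a number 2.8 percentage points lower from compound 3 to compound 4 (within the scatter) and so compound 3 and compound 4 cannot be told apart: this position accepts a methoxy group with no readable consequence at the concentration tested. Compound 4 also gives the first comparison at the double-bonded ring carbon, where cyano in place of methoxycarbonyl gives a number 61 percentage points lower from compound 2 to compound 4 (beyond the scatter) and so, among these compounds, the group on that carbon carries the large step while the aryl methoxy does not. Nothing available explains either step.

On these data alone, it remains open how this aromatic position responds to an amine, a hydroxyl group or a chlorine atom. As far as these compounds go, it also remains open how a carboxylic acid or an amide would fare on the double-bonded ring carbon.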